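A few compounds are considered here, and "the series" means these few. Any claim that something is new, unique, unknown or untested is made for them only; others in the source may bear on it.

Three bis-heteroaryl amidines have been tested in a functional assay on NCI-H522 cells (Homo sapiens) for inhibition, read by sulforhodamine B assay, with a stated time of 48 h; a lower number here means a stronger inhibitor of growth, a higher number a weaker inhibitor of growth. Compound 1 `N=C(N)c1ccc(-c2ccc(-c3cc(Cl)cc(Cl)c3)s2)s1` gives 1910 nM. Compound 2 `COc1ccc(-c2ccc(-c3ccc(C(=N)N)o3)o2)cc1` gives 1090 nM, the lowest of the three numbers, yet the gaps to the other two lie within the scatter of repeated measurements. Compound 3 `N=C(N)c1ccc(-c2ccc(-c3cncc4ccccc34)s2)s1` gives 1650 nM.

Compound 4 `N=C(N)c1ccc(-c2ccc(-c3ccccc3)o2)o1` differs from compound 2 by one change: hydrogen in place of methoxy on an aromatic carbon. For the measured compounds named here, no pair among the measured compounds shows what removing this group alone does, so the expectation rests on the size of the change, which is small. The step of a 1.4-fold higher number from compound 2 to compound 4 (0.14 log units; within the scatter) is expected to be small, in no firm direction, and not beyond the scatter. Compound 4 is therefore estimated at 1500 nM, with a range from 600 nM to 3800 nM.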

Compound 4, concentration for 50% growth inhibition: 1940 nM
Estimate against measurement, compound 4: 1.3-fold (0.11 log units) below, within the range that was stated.
By their numbers in this assay, from the lowest: compounds 2, 3, 1 and 4 (each within the scatter of the next).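

Taking methoxy away and leaving hydrogen, on an aromatic carbon para to a large group, gives the first direct reading of this position: in this assay the result is a 1.8-fold higher number from compound 2 to compound 4 (0.25 log units; within the scatter). This single change therefore does not move the number beyond the usual scatter, so this pair gives no sign that the methoxy matters in this assay. Nothing available here offers an explanation for this result.

Going by these compounds, whether an amine, a carboxylic acid or a longer chain such as butoxy at this place would produce a step beyond the scatter remains open.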